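Thiadiazole Carbonyl in Place of Propanoyl on the Ring Amide

A few compounds are considered here, and "the series" means these few. Any claim that something is new, unique, unknown or untested is made for them only; others in the source may bear on it.

Compound 1, `CCCCNc1nc(N)nc2c1CCN(C(=O)c1ccccc1)C2`, gives 0.8 uM in an assay on HEK293 cells for agonist activity at Toll-like receptor 8 (Homo sapiens), read by a luciferase reporter, with a stated time of 6 h; a higher number here means that more compound is needed for the effect, a lower number that less compound is needed.
Compound 2, `CCCCNc1nc(N)nc2c1CN(Cc1ccccn1)CC2`, gives 0.07 uM in this assay.
Compound 3, `CCCCNc1nc(N)nc2c1CN(C(=O)CC)CC2`, gives 0.4 uM in this assay.

Compound 3 holds the second highest of the three numbers. Compound 1 is its nearest neighbour, and the two values lie within the scatter of each other. Compound 2 is furthest away: a 5.7-fold higher number from compound 2 to compound 3 (0.76 log units; beyond the scatter).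

Compound 4, `CCCCNc1nc(N)nc2c1CN(C(=O)c1csnn1)CC2`, has not yet been measured. It differs from compound 3 in one place: 1,2,3-thiadiazol-4-yl in place of ethyl on a carbonyl carbon.

Going by the values given here, only one measured step touches this region of the molecule, a 5.7-fold higher number from compound 2 to compound 3 (0.76 log units; beyond the scatter), but it exchanges the group on the amine nitrogen in the ring, not the group on the carbonyl carbon, so it bears on the present change only loosely. Among the compounds with values here, no measured step swaps ethyl for an aromatic ring on a carbonyl carbon. Compound 1 does carry an aromatic ring on its carbonyl, though on a differently arranged core, and compound 1 at 0.8 uM and compound 3 at 0.4 uM sit within the scatter of each other. On that basis no step beyond the scatter is expected in this assay, and the expected step is a 1.3-fold lower number from compound 3 to compound 4 (0.12 log units; within the scatter). Compound 4 is therefore estimated at 0.3 uM, in a range from 0.08 uM to 1.2 uM.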

Compound 4, minimum effective concentration: 0.1 uM
Estimate against measurement, compound 4: 3.0-fold (0.48 log units) above, and the stated range covers the measured number.
By their numbers in this assay, from the lowest: compounds 2 and 4 (each within the scatter of the next); then compounds 3 and 1 (each within the scatter of the next).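

In this assay, going by these compounds alone, the group on this carbonyl carbon turns out to matter: 1,2,3-thiadiazol-4-yl in place of ethyl gives a change beyond the scatter (a 4.0-fold lower number from compound 3 to compound 4 (0.60 log units; beyond the scatter)), the only measured step at this carbon. Propanoyl had stood apart from (pyridin-2-yl)methyl on the ring nitrogen, but (1,2,3-thiadiazol-4-yl)carbonyl does not, as its step lies within the scatter (a 1.4-fold higher number from compound 2 to compound 4 (0.15 log units; within the scatter)). So a carbonyl on this nitrogen does not by itself set the number apart from the (pyridin-2-yl)methyl compound, and no evidence is at hand on why the thiadiazole differs from ethyl here.

On these data alone, it remains open whether a plain phenyl on this carbonyl of the shared core would give the same shift as the thiadiazole. A longer chain such as butyl, or an amine on the chain, also remains untested among the compounds shown.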